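The source may report more compounds than this note shows. Statements on the series, on what has been measured and on what is new or still open speak of the compounds shown alone.

Compound 1 `O=C(NC[C@H](NS(=O)(=O)c1ccccc1)C(=O)O)c1ccc(N2CCC[C@H](NC3=NCCCN3)C2)cc1` gives 3500 ug/mL in a physicochemical assay for solubility (a higher number here means a more soluble compound, a lower number a less soluble compound), and compound 3 `O=C(NC[C@H](NS(=O)(=O)c1ccccc1)C(=O)O)c1ccc(N2CCC[C@H](NC3=NCCCN3)C2)cc1F` gives 2800 ug/mL. Among the compounds with values here, the step of a 1.3-fold lower number from compound 1 to compound 3 (0.10 log units; within the scatter) is the only single change measured here, and it concerns a fluoro, not a methoxy. Compound 2 `O=C(NC[C@H](NS(=O)(=O)c1ccccc1)C(=O)O)c1ccc(N2CCC(NC3=NCCCN3)CC2)cc1` stands apart: in this assay it is known only by a limit, < 100 ug/mL, which sits at the limit of < 100 ug/mL in this assay, at which 1 of the 3 values shown sits. Compound 4 `COc1cc(C(=O)NC[C@H](NS(=O)(=O)c2ccccc2)C(=O)O)ccc1N1CCC(NC2=NCCCN2)CC1` differs from compound 2 by methoxy in place of hydrogen on an aromatic carbon. Within the data shown here, no measured step bears on this change, so the expectation rests on compound 2 alone, whose value < 100 ug/mL is a limit rather than a number. Compound 4 is therefore estimated to stay low in this assay, at about 60 ug/mL, between 10 ug/mL and 400 ug/mL. The step that the limit leaves unreadable from compound 2 to compound 4 is expected to be small, with a fair chance that only a limit is again reported.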

Compound 4, solubility: 1300 ug/mL
Compound 4: the middle estimate sits 22-fold (1.34 log units) below what was measured, and the stated range ends below it.
By their numbers in this assay, from the lowest: compound 4; then compounds 3 and 1 (each within the scatter of the next). At a limit, below all of these: compound 2.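

In this assay, methoxy on an aromatic carbon, ortho to a large group and meta to a large group, gives an at least 13-fold higher number from compound 2 to compound 4 (1.11 log units; beyond the scatter), so this position on the core of compound 2 responds strongly to this change. Within the data shown here, the only earlier step on an aromatic carbon, a fluoro on the core of compound 1, was a 1.3-fold lower number from compound 1 to compound 3 (0.10 log units; within the scatter). Compound 2 is known only by a limit: the limit of < 100 ug/mL in this assay, at which 1 of the 4 values shown sits.

Going by these compounds, the full size of the step therefore stays open. So does whether a hydroxyl, an amine or a longer alkoxy chain at this position would give a similar step.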